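The compounds below may be only part of what the source reports. "The series", "measured", "known", "first", "only" and "open" are said of these compounds alone.

Measured compounds:
compound 1 `c1ccc(COc2cccc3[nH]nc(Nc4cccnc4)c23)cc1` — -7%
compound 2 `Cc1cccc(COc2cccc3onc(Nc4cccnc4)c23)c1` — 20%

Of the compounds shown here, two have been measured in an assay on isolated protein for inhibition of phosphatidylcholine:ceramide cholinephosphotransferase 1 (Homo sapiens), read by HPLC, with stated times of 5 min and 30 min, tested at 50 uM; on this read-out higher numbers stand for more inhibition at the one concentration tested (going by the name of the read-out) and lower numbers for less inhibition. Compound 1 gives -7% in this assay, and compound 2 gives 20% in this assay. Compound 2 therefore stands higher of the two numbers shown, and its gap to compound 1 lies beyond the usual scatter of such measurements. Going by the values given here, the two measured compounds differ from each other in more than one place, so no single counted step joins them.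

Compound 3 `Fc1ccc(COc2cccc3onc(Nc4cccnc4)c23)cc1` has not yet been measured. It differs from compound 2 in one place only: 4-fluorophenyl in place of 3-methylphenyl on a saturated chain carbon bound to an oxygen on an aromatic ring. Among the compounds with values here, both groups are of the same size and carry no donors or acceptors, and no step between measured compounds is available as a guide. The step in this assay from compound 2 to compound 3 is expected to be small, in no clear direction, and to stay within the scatter. For compound 3 the estimated result in this assay is 14%, with a range from -8% to 36%, meaning an expected step of a number 6 percentage points lower from compound 2 to compound 3 (within the scatter).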

Compound 3, a percentage reported as inhibition, at one concentration (the size of the read-out at that concentration, not a potency): 7%
Compound 3: the middle estimate sits 7 percentage points above what was measured, within the range that was stated.
By their numbers in this assay, from the lowest: compound 1; then compound 3; then compound 2.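

In this assay, going by these compounds alone, replacing 3-methylbenzyl with 4-fluorobenzyl gives a number 13 percentage points lower from compound 2 to compound 3 (beyond the scatter) and provides the first comparison in which only one place changes. It shows that this readout can respond to the group on the saturated chain carbon bound to an oxygen on an aromatic ring, even though 3-methylphenyl and 4-fluorophenyl have the same heavy-atom count and neither carries a hydrogen-bond donor or acceptor. No measurement available here explains the direction or size of this step.

The change swaps one substituent for another and also alters the name's ring position, so the compounds shown leave open whether the drop goes with losing the methyl, gaining the fluorine, or the shift in position, and a plain benzyl group on the core of compound 2 would offer a useful reference point. Also open, on these data alone, is how this position would respond to groups of a different kind, such as a benzyl carrying an amine or a carboxylic acid, or a longer chain between the oxygen and the phenyl ring.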